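The source may hold more compounds than are shown below. What is called first, only, known or untested is meant among the compounds shown, and "the series" means these compounds.

Compound 1 `CCN(CC)CCCCn1c(N)c(-c2nc3ccccc3[nH]2)c2nc(C#N)c(C#N)nc21` was tested in a functional assay on HeLa cells (Homo sapiens) for antiproliferative activity, read by MTT assay, with a stated time of 48 h (on this read-out higher numbers stand for weaker inhibition and lower numbers for stronger inhibition), where compound 1 gives 10100 nM. Compound 2 `CN(C)CCCCCn1c(N)c(-c2nc3ccccc3[nH]2)c2nc(C#N)c(C#N)nc21` differs from it in one place: (dimethylamino)methyl in place of diethylamino on a saturated chain carbon, four bonds along the chain from an aromatic nitrogen. In this assay compound 2 gives 10800 nM, so the change made a 1.1-fold higher number from compound 1 to compound 2 (0.03 log units; within the scatter). Compound 3 `CCN(CC)CCn1c(N)c(-c2nc3ccccc3n2C)c2nc(C#N)c(C#N)nc21` carries a different core; how its core differs from the core of compound 1 is not broken down here. In this assay compound 3 reaches only a limit, > 50000 nM, which is the limit of > 50000 nM in this assay, at which 1 of the 3 values shown sits. Compound 4 `CN(C)CCCn1c(N)c(-c2nc3ccccc3n2C)c2nc(C#N)c(C#N)nc21` has not yet been measured. It differs from compound 3 in one place: (dimethylamino)methyl in place of diethylamino on a saturated chain carbon, two bonds along the chain from an aromatic nitrogen. This is the same kind of change as that from compound 1 to compound 2, but the place is not the same: there the group sits four bonds along the chain from an aromatic nitrogen, here two bonds along the chain from an aromatic nitrogen. The expected step in this assay is a step that the limit leaves unreadable from compound 3 to compound 4. That expectation rests on compound 3 giving only a limit and on the small size of a 1.1-fold higher number from compound 1 to compound 2 (0.03 log units; within the scatter). Compound 4 is therefore estimated at 60000 nM, expected to lie between 25000 nM and 150000 nM.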

Compound 4, half-maximal inhibitory concentration: 4320 nM
Compound 4: middle estimate off by 14-fold (1.14 log units), on the high side; the whole stated range lies above it.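

In this assay the change from diethylamino to (dimethylamino)methyl does not have the same effect on the two cores: the same change on two cores in this assay, a 1.1-fold higher number (0.03 log units; within the scatter) from compound 1 to compound 2 and an at least 11-fold lower number (1.06 log units; beyond the scatter) from compound 3 to compound 4, at least 12-fold (1.09 log units) apart, beyond the scatter of two such steps. The new step is an at least 11-fold lower number from compound 3 to compound 4 (1.06 log units; beyond the scatter) and has no exact size, as its starting point is only a limit of the assay: the limit of > 50000 nM in this assay, at which 1 of the 4 values shown sits. This does not show why the effect differs: the two pairs differ in their cores and also in where the change sits, four bonds along the chain from an aromatic nitrogen in one pair and two bonds in the other, so neither difference can be singled out as the one that matters.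

The compounds shown leave open whether a 3-(dimethylamino)propyl chain on the core of compound 1 would behave as it does on the core of compound 4. They also leave open whether a ring amine such as morpholine, or a longer chain, would keep the activity of compound 4.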